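The compounds below may be only part of what the source reports. "The series", "measured", "known", "first", "only" and "open" are said of these compounds alone.

Three compounds have numbers in an ADME assay on a cell-free system (plasma, Homo sapiens) for metabolic stability, read by HPLC; on this read-out lower numbers stand for a shorter-lived compound and higher numbers for a longer-lived compound. Compound 1 `CN(/N=N/c1ccc(C#N)cc1)C(=O)CCc1ccc(O)cc1` gives 5.8 h, the lowest of the three. Compound 2 `CCOC(=O)c1ccc(/N=N/N(C)C(=O)CCCCc2ccc(O)cc2)cc1` gives 26.3 h, and compound 3 `CN(/N=N/c1ccc(Br)cc1)C(=O)CCCCc1ccc(O)cc1` gives 162 h. Compound 4 `CC(=O)c1ccc(/N=N/N(C)C(=O)CCc2ccc(O)cc2)cc1` has not yet been measured. It keeps the core of compound 1 and exchanges one group, acetyl in place of cyano on an aromatic carbon, para to a large group: acetyl in place of cyano on an aromatic carbon.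

For the measured compounds named here, only one measured step bears on a change of this kind: a 6.2-fold higher number from compound 2 to compound 3 (0.79 log units; beyond the scatter), with bromo in place of ethoxycarbonyl. That step is modest but beyond the scatter. It involves neither cyano nor acetyl, however, and its core differs from that of compound 1, so it is only a weak guide. Going by the values given here, no measured pair compares acetyl with cyano directly.

From the 5.8 h of compound 1, only a small upward move is expected, within the scatter: a 1.4-fold higher number from compound 1 to compound 4 (0.14 log units; within the scatter). Compound 4 is estimated at 8 h, with an expected range of 3 h to 20 h.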

Compound 4, half-life: 14.6 h
Compound 4: the middle estimate sits 1.8-fold (0.26 log units) below what was measured, within the range that was stated.
By their numbers in this assay, from the lowest: compound 1; then compounds 4 and 2 (each within the scatter of the next); then compound 3.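

For the compounds shown here, for the first time, acetyl and cyano are compared directly on the core of compound 1 in this assay: the exchange at this aromatic carbon, para to a large group, gives a 2.5-fold higher number from compound 1 to compound 4 (0.40 log units; beyond the scatter) and so moves the half-life by a modest step that is not lost in the scatter. Going by these compounds alone, the only earlier step at this place, a 6.2-fold higher number from compound 2 to compound 3 (0.79 log units; beyond the scatter) on a different core, involved neither group, so this result is the first to show that replacing cyano with acetyl itself shifts the number upward. Nothing available accounts for the size or direction of this step.

Going by these compounds, whether acetyl in place of cyano gives a similar step on the core of compound 2 remains open. So does how an amine, a carboxylic acid or a methoxy group would fare at this place.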